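Three Amides Beyond the Limit and a Fourth to Measure

This account rests on a few compounds, and the source may have more. Where it says the series, first, only, none or still open, it means among the compounds named here.

Measured compounds, all tested in a toxicity assay on THP-1 cells (Homo sapiens) for inhibition; a lower number here means that less compound is tolerated, a higher number that more compound is tolerated:
Compound 1 `COc1ccc(-c2cnc(NC(=O)c3ccccn3)n2C)cc1`: > 100000 nM, a limit of this assay.
Compound 2 `COc1ccc(-c2cnc(NC(=O)C3CCCC3)n2C)cc1`: > 100000 nM, again only a limit.
Compound 3 `COc1ccc(-c2cnc(NC(=O)c3ccn[nH]3)n2C)cc1`: > 100000 nM, likewise a limit.

All three values sit at the same limit (the limit of > 100000 nM in this assay, at which 3 of the 3 values shown sit), so none of them is a number. The three steps between them, a step that the two limits leave unreadable from compound 1 to compound 2, a step that the two limits leave unreadable from compound 1 to compound 3 and a step that the two limits leave unreadable from compound 2 to compound 3, therefore cannot be sized. Compound 3 thus stands at the limit, level with the other two as far as the data can tell.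

Compound 4 `COc1ccc(-c2cnc(NC(=O)C3CCOCC3)n2C)cc1` is not yet measured. It differs from compound 3 by oxan-4-yl in place of 1H-pyrazol-5-yl on a carbonyl carbon. Every measured step bearing on this position is unreadable, and each variant at the carbonyl carbon, whether aromatic or saturated, stayed at the limit. The expectation is therefore that the step of a number no higher from compound 3 to compound 4 (the limit leaves the size open) is none beyond the scatter. Compound 4 is expected to give about 100000 nM, in the range 50000 nM to 300000 nM, most likely reported again as a limit.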

Compound 4, half-maximal cytotoxic concentration: > 100000 nM
Compound 4 gave a limit, no number; the forecaster's own chance of this, stated with the estimate: 85%; the middle value lies on the limit itself.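

For the compounds shown here, compound 4 sits at the same limit as compound 1, compound 2 and compound 3, so no step from any of them to compound 4 can be read: the limit of > 100000 nM in this assay, at which 4 of the 4 values shown sit. The compounds shown leave open whether changing the group on the carbonyl carbon alters the result in this assay at all.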